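Replacing Dimethoxyphenyl with Dichlorophenyl in Compound 3

The source may hold more compounds than are shown below. What is called first, only, known or untested is meant among the compounds shown, and "the series" means these compounds.

Three compounds have numbers in a functional assay on HCT-116 cells (Homo sapiens) for antiproliferative activity, read by sulforhodamine B assay, with a stated time of 48 h; a lower number here means a stronger inhibitor, a higher number a weaker inhibitor. Compound 1 `COc1cccc(/C=C/C(=O)c2c(O)cc(OC)cc2OC)c1` gives 3100 nM, and compound 2 `COc1cc(O)c(C(=O)/C=C/c2cc(Cl)cc(Cl)c2)c(OC)c1` gives 1900 nM. Compound 3 `COc1cc(OC)c(C(=O)/C=C/c2ccc(OC)c(OC)c2)c(OCC=C(C)C)c1` gives 5700 nM, a value within the usual scatter of compound 1 but weaker than compound 2 by more than the scatter. Compound 4 `COc1cc(OC)c(C(=O)/C=C/c2cccc(Cl)c2Cl)c(OCC=C(C)C)c1` has 2,3-dichlorophenyl in place of 3,4-dimethoxyphenyl on a double-bonded chain carbon bound to a double-bonded chain carbon. Going by the values given here, no measured pair shows this change directly. Compound 2, which also carries a dichlorophenyl group, gives 1900 nM, so a lower number is expected for compound 4. The expected step is modest, a 1.9-fold lower number from compound 3 to compound 4 (0.28 log units; within the scatter), and may stay within the scatter. For compound 4 the estimate is 3000 nM, with an expected range from 1100 nM to 8000 nM.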

Compound 4, half-maximal inhibitory concentration: 1900 nM
Estimate against measurement, compound 4: 1.6-fold (0.20 log units) above; the range from low to high includes it.
By their numbers in this assay, from the lowest: compounds 2, 4, 1 and 3 (each within the scatter of the next, the first and the last beyond it).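

Within this assay, the exchange of 3,4-dimethoxyphenyl for 2,3-dichlorophenyl gives a 3.0-fold lower number from compound 3 to compound 4 (0.48 log units; beyond the scatter) and is the first direct comparison at this position, where the earlier compounds offered none. It shows that, on the core of compound 3, this change alone moves the number beyond the scatter. Nothing available explains the drop. Still open, as far as these compounds go, is whether losing the two methoxy groups or gaining the two chlorines drives it. An unsubstituted phenyl group, or a phenyl group bearing an amine, at this place could begin to separate the two.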